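The compounds below may be only part of what the source reports. "The series", "measured", "known", "first", "only" and "open" are said of these compounds alone.

Working notes on the series, step from compound 3 to compound 4.

For the measured compounds named here, compound 3 `CCC(C)OC(=O)C(O)Cn1cnc2c(N)ncnc21` is the most tolerated of the three compounds with numbers so far. In a functional assay on PRK cells (Oryctolagus cuniculus) for cytotoxicity (a lower number here means that less compound is tolerated, a higher number that more compound is tolerated), compound 3 gives > 400 ug/mL, which is a limit of the assay and not a number. Compound 1 `CCCCCCCCOC(=O)C(O)Cn1cnc2c(N)ncnc21` gives 100 ug/mL in this assay. Compound 2 `Nc1ncnc2c1ncn2CC(O)C(=O)OCc1ccco1` gives 40 ug/mL in this assay. The two steps reaching compound 3, an at least 4.0-fold higher number from compound 1 to compound 3 (0.60 log units; beyond the scatter) and an at least 10-fold higher number from compound 2 to compound 3 (1.00 log units; beyond the scatter), both run upward, while a 2.5-fold lower number from compound 1 to compound 2 (0.40 log units; beyond the scatter) runs the other way; all three steps change only the group on the oxygen next to a carbonyl group.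

Compound 4 `CCOC(=O)C(O)Cn1cnc2c(N)ncnc21` continues along this same position: hydrogen in place of ethyl on a saturated chain carbon bound to an oxygen next to a carbonyl group and a saturated chain carbon. The steps from octyl and from (furan-2-yl)methyl to sec-butyl were at least modest and upward, so a further step in that direction is expected, though compound 3 already sits at the limit of > 400 ug/mL in this assay, at which 1 of the 3 values shown sits, and a repeat of that limit is the likeliest outcome. Compound 4 is expected to give 500 ug/mL, with a range of 250 ug/mL to 1000 ug/mL in this assay, which means an expected step that the limit leaves unreadable from compound 3 to compound 4.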

Compound 4, minimum cytotoxic concentration: > 400 ug/mL
Compound 4: a limit, no number; the forecaster's own chance of this, stated with the estimate: 70%; the middle value is on the limit's open side.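

In this assay compound 4 gives > 400 ug/mL as a limit of the assay and not a number. The step from compound 3 to compound 4 cannot be read, yet the ethoxy group also stands clear of the two other esters, with an at least 4.0-fold higher number from compound 1 to compound 4 (0.60 log units; beyond the scatter) and an at least 10-fold higher number from compound 2 to compound 4 (1.00 log units; beyond the scatter) both upward and beyond the scatter. Going from sec-butoxy to ethoxy therefore brings no readable loss of tolerance, and the top of this series now rests on two compounds rather than one: the limit of > 400 ug/mL in this assay, at which 2 of the 4 values shown sit.

From the compounds shown here alone, how far past the limit compound 3 and compound 4 lie stays open, so no order of sec-butyl and ethyl can be given. Also open, going by these compounds, is whether a hexyl chain or a free carboxylic acid would stay at the limit.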